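Carbamoylmethoxy ether in place of prenyl ether on a flavonol

The source may hold more compounds than are shown below. What is called first, only, known or untested is meant among the compounds shown, and "the series" means these compounds.

Measured compounds:
compound 1, `C=CCCOc1cc(O)c2c(=O)c(O)c(-c3ccc4c(c3)OC(c3ccc(OCCC=C)c(OC)c3)C(CO)O4)oc2c1`, 36200 nM
compound 2, `COc1cc(C2Oc3cc(-c4oc5cc(OCC=C(C)C)cc(O)c5c(=O)c4O)ccc3OC2CO)ccc1O`, 23300 nM
compound 3, `COc1cc(C2Oc3cc(-c4oc5cc(OCC(=O)N6CCCC6)cc(O)c5c(=O)c4O)ccc3OC2CO)ccc1OCC(=O)N1CCCC1`, 900 nM

Three members of one series have been tested in a functional assay on liver (Rattus norvegicus, strain Sprague-Dawley) for inhibition, with a stated time of 1 h; a higher number here means a weaker inhibitor, a lower number a stronger inhibitor. Compound 2 stands second highest of the three numbers: its nearest neighbour is compound 1, whose number lies within the usual scatter of it, while compound 3 lies far beyond the scatter with a much lower number. Compound 2 and compound 1 therefore cannot be told apart on these data, whereas compound 3 is clearly the stronger inhibitor of the three.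

The new compound 4, `CCN(CC)C(=O)COc1cc(O)c2c(=O)c(O)c(-c3ccc4c(c3)OC(c3ccc(O)c(OC)c3)C(CO)O4)oc2c1`, is derived from compound 2 by a single change: diethylcarbamoyl in place of 2-methylprop-1-en-1-yl on a saturated chain carbon bound to an oxygen on an aromatic ring. The rest of the shared core, including the free phenol on the outer ring, is kept as in compound 2.

Among the compounds with values here, no step between measured compounds isolates this exact change, so the expectation rests on the spread of the numbers. Because compound 3 gives 900 nM in this assay, a move toward a lower number is expected for compound 4, though smaller than the full gap between compound 2 and compound 3. The step from compound 2 is estimated at a 4.7-fold lower number from compound 2 to compound 4 (0.67 log units; beyond the scatter). Compound 4 is expected to give 5000 nM, with a range from 1500 nM to 15000 nM.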

Compound 4, half-maximal inhibitory concentration: 700 nM
For compound 4 the middle estimate is 7.1-fold (0.85 log units) above the measured one; measured number below the stated range.
By their numbers in this assay, from the lowest: compounds 4 and 3 (each within the scatter of the next); then compounds 2 and 1 (each within the scatter of the next).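

In this assay, the exchange of (3-methylbut-2-en-1-yl)oxy for (diethylcarbamoyl)methoxy on the aromatic ring gives a 33-fold lower number from compound 2 to compound 4 (1.52 log units; beyond the scatter), with the free phenol on the outer ring kept. Within the data shown here, this is the first step that isolates one change, since the earlier compounds differ from one another in more than one place; it shows that the group carried on this oxygen alone can shift the number well beyond the scatter, with no second change on the outer ring needed. Nothing available here accounts for the size of this step.

The compounds shown leave open which part of the diethylcarbamoyl group the step depends on, since a carboxylic acid, an ethyl ester or a secondary amide on the same methoxy link would separate the carbonyl from the diethylamino part. They also leave open whether a pyrrolidine amide at this position, with the free phenol on the outer ring kept, behaves as the diethylcarbamoyl group does.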